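Swapping the aryl group on a fused bicyclic core

The source may report more compounds than this note shows. Statements on the series, on what has been measured and on what is new or still open speak of the compounds shown alone.

Measured so far:
compound 1, `c1cn(-c2ncnc3c2cnn3CCN2CCCCC2)cn1`: 13800 nM in an assay on HEK293 cells for displacement of a labelled ligand from Sigma non-opioid intracellular receptor 1 (Homo sapiens), read by scintillation counting, with a stated time of 120 min; on this read-out higher numbers stand for weaker inhibition and lower numbers for stronger inhibition
compound 2, `COc1ccc(-c2ncnc3c2cnn3CCN2CCCCC2)cc1`: 531 nM in this assay
compound 3, `Cc1ccc(C)c(-c2ncnc3c2cnn3CCN2CCCCC2)c1`: 63 nM in this assay

Compound 3 gives the lowest number of the three. Its nearest neighbour is compound 2, with an 8.4-fold lower number from compound 2 to compound 3 (0.93 log units; beyond the scatter); compound 1 lies furthest away, with a 220-fold lower number from compound 1 to compound 3 (2.34 log units; beyond the scatter). Both steps lie beyond the scatter, so compound 3 stands alone as the most potent of the measured set.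

Compound 4, `Cn1cc(-c2ncnc3c2cnn3CCN2CCCCC2)cn1`, has not yet been measured. It differs from compound 3 in a single place: 1-methyl-1H-pyrazol-4-yl in place of 2,5-dimethylphenyl on an aromatic carbon.

Among the compounds with values here, two measured steps bear on this change. The step from an azole to the dimethylphenyl group, a 220-fold lower number from compound 1 to compound 3 (2.34 log units; beyond the scatter), is large, and the step from a methoxyphenyl group to the same dimethylphenyl group, an 8.4-fold lower number from compound 2 to compound 3 (0.93 log units; beyond the scatter), is modest. Both show that compound 3 carries the group giving the lowest number, and that the five-membered azole in compound 1 gives the highest. Since compound 4 again carries a five-membered azole, now carbon-linked and bearing a methyl group, a step upward in this assay from compound 3 is expected, probably large, though perhaps not as large as for compound 1; the expected step is a 40-fold higher number from compound 3 to compound 4 (1.60 log units; beyond the scatter). Compound 4 is therefore estimated at 2500 nM, in the range 600 nM to 10000 nM.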

Compound 4, inhibition constant: 9460 nM
The estimate for compound 4 lay 3.8-fold (0.58 log units) below the measured number; low and high end bracket the measured number.
By their numbers in this assay, from the lowest: compound 3; then compound 2; then compounds 4 and 1 (each within the scatter of the next).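

In this assay, replacing the aryl group with 1-methyl-1H-pyrazol-4-yl gives a 150-fold higher number from compound 3 to compound 4 (2.18 log units; beyond the scatter) and an 18-fold higher number from compound 2 to compound 4 (1.25 log units; beyond the scatter), so the loss seen earlier with 1H-imidazol-1-yl also appears with an azole joined to the core through carbon and carrying a methyl group. The two azoles cannot be told apart, with a 1.5-fold lower number from compound 1 to compound 4 (0.16 log units; within the scatter), so neither the change of attachment from ring nitrogen to ring carbon nor the added methyl group separates them as a pair in this assay. Across the four compounds, the two with a five-membered aromatic ring at this position give higher numbers than the two with a six-membered aromatic ring of carbon only, and no compound here goes against that split.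

The compounds shown leave open where an unsubstituted phenyl, a pyridyl group or a thiophene would fall, and so whether ring size, ring nitrogen or the substituents on the phenyl ring governs the result. No measurement given here accounts for the gap between the two pairs.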